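This account rests on a few compounds, and the source may have more. Where it says the series, first, only, none or still open, it means among the compounds named here.

Values in an ADME assay on HEK-293T cells (Homo sapiens) for cytotoxicity, read by CCK-8 assay, with a stated time of 48 h; on this read-out lower numbers stand for stronger inhibition and higher numbers for weaker inhibition:
- compound 1 `O=C(NCCNS(=O)(=O)c1ccc(-c2ccccc2OCc2cccc(O)c2)s1)Nc1cc(C(F)(F)F)cc(C(F)(F)F)c1`: > 20000 nM
- compound 2 `Nc1ccc(Oc2ccccc2-c2ccc(S(=O)(=O)NCCNC(=O)Nc3cc(C(F)(F)F)cc(C(F)(F)F)c3)s2)cc1`: > 20000 nM
- compound 3 `O=C(NCCNS(=O)(=O)c1ccc(-c2ccccc2Oc2ccc([N+](=O)[O-])c([N+](=O)[O-])c2)s1)Nc1cc(C(F)(F)F)cc(C(F)(F)F)c1`: > 50000 nM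

All three values are limits of the assay, not numbers. Compound 3 stands at the limit of > 50000 nM in this assay, at which 1 of the 3 values shown sits. Compound 1 and compound 2 stand at the limit of > 20000 nM in this assay, at which 2 of the 3 values shown sit.

The next compound is compound 4 `O=C(NCCNS(=O)(=O)c1ccc(-c2ccccc2Oc2ccc(O)c(O)c2)s1)Nc1cc(C(F)(F)F)cc(C(F)(F)F)c1`, with 3,4-dihydroxyphenyl in place of 3,4-dinitrophenyl on an oxygen on an aromatic ring.

Three measured steps change the same place: a step that the two limits leave unreadable from compound 1 to compound 3, a step that the two limits leave unreadable from compound 2 to compound 3 and a step that the two limits leave unreadable from compound 1 to compound 2. None has a readable size, and all three groups leave the read-out at a limit. These steps therefore give no direction, and no step beyond the usual scatter is expected in this assay. The estimated step is an at least 1.4-fold lower number from compound 3 to compound 4 (0.15 log units; that floor lies within the scatter).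

A limit is again the likely report. For compound 4 the expected value is 35000 nM, with an estimated range of 14000 nM to 80000 nM.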

Compound 4, half-maximal inhibitory concentration: 17100 nM
Compound 4: the middle estimate sits 2.0-fold (0.31 log units) above what was measured, and the stated range covers the measured number.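

In this assay, for the compounds shown here, compound 4 gives 17100 nM, the first value at this place on the oxygen that is a number and not a limit of the assay. Putting 3,4-dihydroxyphenyl in place of 3,4-dinitrophenyl gives an at least 2.9-fold lower number from compound 3 to compound 4 (0.46 log units; beyond the scatter), so a change at this place can move the read-out beyond the scatter. The comparisons with the other two groups are weaker, at an at least 1.1-fold lower number from compound 2 to compound 4 (0.06 log units; that floor lies within the scatter) and an at least 1.1-fold lower number from compound 1 to compound 4 (0.06 log units; that floor lies within the scatter), so these floors do not set compound 4 apart from compound 1 or compound 2.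

As far as these compounds go, the steps among compound 1, compound 2 and compound 3 cannot be read, and the true distance from compound 4 to compound 1 and compound 2 stays open: the limit of > 20000 nM in this assay, at which 2 of the 4 values shown sit. Whether a carboxylic acid on the ring in place of the two hydroxyl groups would also give a number at this place remains open.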